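Methyl-to-methoxy swap on the aryl ring of a dioxide series

The compounds below may be only part of what the source reports. "The series", "measured", "known", "first", "only" and "open" are said of these compounds alone.

Compound 1 `Cc1ccc(-c2c(C#N)[n+]([O-])c3cc(Cl)c(Cl)cc3[n+]2[O-])cc1` and compound 2 `Cc1ccc(-c2c(C#N)[n+]([O-])c3cc(C)c(C)cc3[n+]2[O-])cc1` share a common core but differ in more than one place, so the difference between the two cores is not broken down here. Compound 3 `COc1ccc(-c2c(C#N)[n+]([O-])c3cc(Cl)c(Cl)cc3[n+]2[O-])cc1` is the methoxy counterpart of compound 1, and compound 4 `COc1ccc(-c2c(C#N)[n+]([O-])c3cc(C)c(C)cc3[n+]2[O-])cc1` is the methoxy counterpart of compound 2.

In a physicochemical assay for lipophilicity, measured as octanol-water partition (a lower number here means a more polar compound, a higher number a more lipophilic compound), compound 1 gives 3.1, compound 2 gives 2.57, and compound 3 gives 2.33. Compound 3 differs from compound 1 by methoxy in place of methyl on an aromatic carbon, a change that gave a number 0.77 log units lower from compound 1 to compound 3 (beyond the scatter). The values of compound 2 and compound 3 lie within the scatter of each other.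

Compound 4 differs from compound 2 by methoxy in place of methyl on an aromatic carbon, the same change at the same place. The expectation for this assay is a step of a number 0.77 log units lower from compound 2 to compound 4 (beyond the scatter) from compound 2 to compound 4, resting on the measured step from compound 1 to compound 3. Compound 4 is therefore estimated at 1.8 in this assay, with a range from 1.45 to 2.15.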

Compound 4, partition coefficient: 2.06
Compound 4: middle estimate off by 0.26 log units, on the low side; low and high end bracket the measured number.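

In this assay the change from 4-methylphenyl to 4-methoxyphenyl gives a number 0.51 log units lower from compound 2 to compound 4 (beyond the scatter) and runs the same way as a number 0.77 log units lower from compound 1 to compound 3 (beyond the scatter) on the other core, with both steps printed as beyond the scatter. The direction of the change therefore carries over between these two cores, but the size does not repeat exactly, and two pairs cannot fix a size to expect or show that the direction would hold on a third core. No measured evidence is at hand to account for the direction of the step or for the difference in its size between the two cores.

Among the compounds shown, only methyl and methoxy stand at this place on the aromatic ring, so it remains open whether a longer chain such as ethoxy, an amine or a carboxylic acid would follow the same course. Also open is how this change behaves on any core beyond the two shown here.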